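This account rests on a few compounds, and the source may have more. Where it says the series, first, only, none or still open, it means among the compounds named here.

Measured compounds:
- compound 1, `Cn1c(=O)c(S(=O)(=O)c2ccc(F)cc2)cc2cnc(Nc3cccc4[nH]ccc34)nc21`: 750 nM
- compound 2, `Cn1c(=O)c(S(=O)(=O)Cc2ccc(F)cc2F)cc2cnc(Nc3ccc4[nH]ccc4c3)nc21`: 1000 nM
- compound 3, `O=c1c(S(=O)(=O)c2ccc(F)cc2F)cc2cnc(Nc3ccc4[nH]ccc4c3)nc2n1C1CC1`: 500 nM

All three were tested in a functional assay on K562 cells (Homo sapiens) for inhibition, read by trypan blue exclusion, with a stated time of 72 h; on this read-out higher numbers stand for weaker inhibition and lower numbers for stronger inhibition. Compound 2 shows the number that stands at the top of the three, but its distance to compound 1 and to compound 3 is within the usual scatter of repeated measurements, so none of the three can be called stronger or weaker than the others on this evidence.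

Compound 4, `Cn1c(=O)c(S(=O)(=O)Nc2ccc(F)cc2F)cc2cnc(Nc3ccc4[nH]ccc4c3)nc21`, has not been measured yet. It differs from compound 2 in one place:

(2,4-difluorophenyl)amino in place of 2,4-difluorobenzyl on a sulfonyl sulfur

The change keeps the same count of heavy atoms and the same ring, and adds one hydrogen-bond donor. For the measured compounds named here, nothing among the measured compounds tests this change, since no pair of them differs in this one place alone. The measured numbers cluster closely, and the change is small in size, so no step beyond the scatter is expected in either direction in this assay.

Compound 4 is therefore estimated to give 700 nM in this assay, within a range of 250 nM to 2000 nM. That estimate means a step of a 1.4-fold lower number from compound 2 to compound 4 (0.15 log units; within the scatter), which is expected to stay within the scatter.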

Compound 4, half-maximal inhibitory concentration: 5000 nM
Beside the measured number, compound 4's estimate is 7.1-fold (0.85 log units) below it; the whole stated range lies below it.
By their numbers in this assay, from the lowest: compounds 3, 1 and 2 (each within the scatter of the next); then compound 4.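

In this assay, for the compounds shown here, the group on the sulfonyl sulfur proves able to shift the read-out: (2,4-difluorophenyl)amino in place of 2,4-difluorobenzyl gives a 5.0-fold higher number from compound 2 to compound 4 (0.70 log units; beyond the scatter), which means weaker inhibition and is the only step in this set that lies beyond the scatter. The two groups have the same count of heavy atoms and the same ring, yet the entering group swaps one carbon for one nitrogen and adds one hydrogen-bond donor, so even a change this small in size can matter at this position. The compounds offer no measurement that accounts for the loss, so it stands as an observation without an explanation.

On these data alone, it remains open whether the nitrogen itself or the hydrogen it carries goes with the weaker inhibition, a question that a methylamino group carrying the same 2,4-difluorophenyl ring could help to separate. Also unsettled are how a longer chain, such as 2-(2,4-difluorophenyl)ethyl, would fare on the sulfonyl sulfur and whether the same swap would give a similar step on the other compounds shown.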